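Extending a Hydroxymethyl Chain on a Coumarin-Type Series

A few compounds are considered here, and "the series" means these few. Any claim that something is new, unique, unknown or untested is made for them only; others in the source may bear on it.

Of the compounds shown here, three share a common core and have been tested in an assay for inhibition of Amine oxidase [flavin-containing] A (Homo sapiens), read by fluorescence, using microsomes, with a stated time of 30 min; on this read-out higher numbers stand for weaker inhibition and lower numbers for stronger inhibition. Compound 1 `Cc1c(C)c2ccc(OCC3CCN(Cc4ccc(CO)cc4)CC3)cc2oc1=O` gives 1400 nM, the lowest number of the three. Compound 3 `Cc1cc2ccc(OCC3CCN(Cc4cccc(CO)c4)CC3)cc2oc1=O` gives 3900 nM, and compound 2 `Cc1cc(=O)oc2cc(OCC3CCN(Cc4ccc(CO)cc4)CC3)ccc12` gives 11000 nM. Going by the values given here, the only single-point step among them, a 7.9-fold higher number from compound 1 to compound 2 (0.90 log units; beyond the scatter), removes a methyl from the core and weakens inhibition.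

Compound 4 `Cc1c(C)c2ccc(OCC3CCN(Cc4ccc(CCO)cc4)CC3)cc2oc1=O` has not yet been measured. It differs from compound 1 by hydroxymethyl in place of hydroxy on a saturated chain carbon bound to an aromatic carbon: the alcohol-bearing chain on the outer benzyl group grows by one carbon, while the core of compound 1 is kept whole.

Among the compounds with values here, no measured step touches this part of the molecule; the step from compound 1 to compound 2 concerns the core methyl and does not bear on the chain length. With nothing directly comparable, the expectation is that lengthening the chain leaves the number close to that of compound 1, perhaps drifting slightly upward. Compound 4 is therefore estimated at 1800 nM, with a likely range from 600 nM to 5500 nM, an expected step of a 1.3-fold higher number from compound 1 to compound 4 (0.11 log units; within the scatter).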

Compound 4, half-maximal inhibitory concentration: 1700 nM
Beside the measured number, compound 4's estimate is 1.1-fold (0.02 log units) above it; low and high end bracket the measured number.
By their numbers in this assay, from the lowest: compounds 1 and 4 (each within the scatter of the next); then compound 3; then compound 2.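

In this assay, extending the hydroxymethyl group to 2-hydroxyethyl on the outer benzyl group gives a 1.2-fold higher number from compound 1 to compound 4 (0.08 log units; within the scatter). Going by these compounds alone, this is the first measured single change to the length of this chain, and it shows that one added carbon, with the alcohol kept at the chain end, does not shift the number beyond the scatter. No supporting measurement offers a reason for this result.

A single added carbon says little about the wider limits of this position, so a longer chain such as 3-hydroxypropyl, or an amine or a carboxylic acid in place of the alcohol, remains an open question. On these data alone, it is also open whether 4-(2-hydroxyethyl)benzyl would give a similar result on the core of compound 2, which has one methyl fewer.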